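The compounds below may be only part of what the source reports. "The series", "measured", "known", "first", "only" and "open" are said of these compounds alone.

Measured so far in a functional assay on NCI/ADR-RES cells (Homo sapiens) for cytotoxicity, read by sulforhodamine B assay, with a stated time of 48 h, tested at 1 uM; a lower number here means a stronger effect, a higher number a weaker effect of the compound at the concentration tested:

- compound 1 `COc1cc(-c2cc(/C=C/C(=O)c3ccc(Cl)c(Cl)c3)[nH]n2)cc(OC)c1OC`: 92%
- compound 2 `COc1ccc(C(=O)/C=C/c2cc(-c3cc(OC)c(OC)c(OC)c3)n[nH]2)cc1OC`: 90%

Compound 2 holds the lowest of the two numbers, but its nearest neighbour is compound 1, and the step of a number 2 percentage points lower from compound 1 to compound 2 (within the scatter) lies within the scatter, so the two compounds cannot be told apart on these numbers. That step exchanged the 3,4-dichlorophenyl on the carbonyl carbon for 3,4-dimethoxyphenyl and left the read-out essentially where it was.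

Compound 3 `COc1ccc(C(=O)/C=C/c2cc(-c3cc(OC)c(OC)c(OC)c3)n[nH]2)cc1` differs from compound 2 by hydrogen in place of methoxy on an aromatic carbon, which, cut one bond further out, reads 3,4-dimethoxyphenyl to 4-methoxyphenyl. Within the data shown here, no measured step in this set removes a methoxy from that ring; the only step available, from compound 1 to compound 2, changed the same ring and stayed within the scatter. Among the measured compounds shown here, with both measured values sitting close together and no step pointing either way, the expectation for compound 3 is no movement beyond the scatter, a step of a number 1 percentage points higher from compound 2 to compound 3 (within the scatter) in this assay. Compound 3 is therefore estimated at 91%, within 80% to 100%.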

Compound 3, a percentage reported as activity, at one concentration (the size of the read-out at that concentration, not a potency): 90%
Estimate against measurement, compound 3: 1 percentage points above, within the range that was stated.
By their numbers in this assay, from the lowest: compounds 2, 3 and 1 (each within the scatter of the next).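

Hydrogen in place of methoxy on the aromatic carbon ortho to a methoxy group gives no change at the digits printed from compound 2 to compound 3 (within the scatter) in this assay, so at this single concentration the read-out does not register the loss of this methoxy, a change that the earlier pair, which differed by a full exchange of the ring's substituents, could not isolate. With 4-methoxyphenyl on the carbonyl carbon, the comparison with the dichlorinated ring gives a number 2 percentage points lower from compound 1 to compound 3 (within the scatter), which means that 3,4-dichlorophenyl, 3,4-dimethoxyphenyl and 4-methoxyphenyl on the carbonyl carbon cannot be told apart here, whether the ring carries chlorines, two methoxy groups or one. No independent measurement is available to account for this flat result.

On these data alone, whether a different kind of group at this aromatic carbon, such as an amine, a carboxylic acid or a longer chain like butoxy, would move the number beyond the scatter remains open, as does the effect of replacing the remaining methoxy with hydrogen to give an unsubstituted phenyl. The read-out at one concentration also leaves open whether these three compounds would separate at higher concentrations, since it gives no potency.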